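Removing the benzylic ring methyl: compound 1 to compound 4

A few compounds are considered here, and "the series" means these few. Any claim that something is new, unique, unknown or untested is made for them only; others in the source may bear on it.

Measured so far in a functional assay on aorta (Rattus norvegicus, strain Sprague-Dawley); a higher number here means that more compound is needed for the effect, a lower number that less compound is needed:
compound 1 `Cc1ccccc1COc1nc2c(cc1-c1nc(N)cc(N)n1)c(C)nn2-c1ccccc1` — 290 nM
compound 2 `Cc1nn(-c2ccccc2)c2nc(OCc3ccccc3F)c(-c3nc(N)c(N)c(N)n3)cc12` — 960 nM
compound 3 `COC(=O)Nc1c(N)nc(-c2cc3c(C)nn(-c4ccccc4)c3nc2OCc2ccccc2F)nc1N` — 5800 nM

Compound 1 stands lowest of the three numbers; compound 2 gives 960 nM, the nearest, and compound 3 gives 5800 nM, the furthest, both gaps beyond the scatter. Going by the values given here, the one step within a single change, a 6.0-fold higher number from compound 2 to compound 3 (0.78 log units; beyond the scatter), concerns a methoxycarbonyl on a nitrogen of the shared core and is modest.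

Compound 4 `Cc1nn(-c2ccccc2)c2nc(OCc3ccccc3)c(-c3nc(N)cc(N)n3)cc12` is reached from compound 1 by hydrogen in place of methyl on an aromatic carbon. Among the compounds with values here, no measured step touches the benzyloxy part, so nothing here bears directly on it; the step from compound 2 to compound 3 only shows that a single added group on this scaffold can move this assay modestly. A hydrogen replacing a methyl is a smaller change than that, and a step of no more than about the scatter, in either direction, is expected. Compound 4 is therefore expected to give roughly 400 nM, within 150 nM to 1100 nM, which would be a step of a 1.4-fold higher number from compound 1 to compound 4 (0.14 log units; within the scatter).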

Compound 4, half-maximal effective concentration: 10800 nM
For compound 4 the middle estimate is 27-fold (1.43 log units) below the measured one; the whole stated range lies below it.
By their numbers in this assay, from the lowest: compound 1; then compound 2; then compounds 3 and 4 (each within the scatter of the next).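

In this assay the change from 2-methylbenzyl to benzyl gives a 37-fold higher number from compound 1 to compound 4 (1.57 log units; beyond the scatter) and so marks this aromatic carbon, ortho to a large group, as a place where the series responds strongly. Losing this one methyl moves the number further than the one earlier single change, which is a 6.0-fold higher number from compound 2 to compound 3 (0.78 log units; beyond the scatter) and adds methoxycarbonyl, so the size of a change does not track the size of its step in these compounds. No measurement available here explains the step.

From the compounds shown here alone, whether methyl is specifically required stays open: ethyl, methoxy or chlorine on this carbon would test that. The 2-fluorobenzyl group of compound 2 cannot settle it, since compound 2 also differs from compound 1 in a second place.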